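The source may report more compounds than this note shows. Statements on the series, on what has been measured and on what is new or still open speak of the compounds shown alone.

In a functional assay on DU-145 cells (Homo sapiens) for inhibition, read by MTT assay, with a stated time of 72 h (a higher number here means a weaker inhibitor, a lower number a stronger inhibitor), compound 1 `O=C1C=C(N2CCN(c3ccc(Cl)cc3)CC2)C(=O)c2ccccc21` gives 29500 nM. Compound 2 `O=C1C=C(N2CCN(c3ccc(Br)cc3)CC2)C(=O)c2ccccc21` gives > 50000 nM, which is a limit of the assay and not a number. Compound 3 `COc1ccc(N2CCN(C3=CC(=O)c4ccccc4C3=O)CC2)cc1` has methoxy in place of bromo on an aromatic carbon, para to a large group (methoxy in place of bromo on an aromatic carbon). For the measured compounds named here, the only measured step at this same place is an at least 1.6-fold higher number from compound 1 to compound 2 (0.22 log units; that floor lies within the scatter), with bromo in place of chloro on an aromatic carbon. That single step sets no clear direction, so no change beyond the scatter is expected. The expected step is an at least 1.4-fold lower number from compound 2 to compound 3 (0.15 log units; that floor lies within the scatter). Compound 3 is estimated at 35000 nM, with an expected range of 12000 nM to 70000 nM.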

Compound 3, half-maximal inhibitory concentration: 46100 nM
Beside the measured number, compound 3's estimate is 1.3-fold (0.12 log units) below it; the measured number falls inside the stated range.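

Methoxy is a third group at this place, and swapping chloro for it gives a 1.6-fold higher number from compound 1 to compound 3 (0.19 log units; within the scatter), so a group with an oxygen changes little that can be told apart here. The swap from bromo reads only as an at least 1.0-fold lower number from compound 2 to compound 3 (0.03 log units; that floor lies within the scatter). That step is just a floor, since compound 2 has a limit of the assay and not a number: the limit of > 50000 nM in this assay, at which 1 of the 3 values shown sits.

Going by these compounds, whether an amine, a carboxylic acid or a longer chain at this place would move the number beyond the scatter stays open. So does whether any group here can do so.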